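This account rests on a few compounds, and the source may have more. Where it says the series, first, only, none or still open, it means among the compounds named here.

In an ADME assay on MDCK cells (Canis lupus familiaris) for cytotoxicity, read by MTT assay, with a stated time of 24 h (on this read-out lower numbers stand for higher toxicity in this test and higher numbers for lower toxicity in this test), compound 1 (`COc1ccc(S(=O)(=O)N(CCC#N)Cc2cccs2)cc1`) gives > 198000 nM as a limit. Compound 2 (`N#CCCN(Cc1cccs1)S(=O)(=O)c1ccc(C(F)(F)F)cc1`) gives > 178000 nM as a limit as well. Compound 3 (`N#CCCN(Cc1cccs1)S(=O)(=O)c1ccc(N)cc1`) gives > 207000 nM as a limit too. Compound 2 therefore stands without a number of its own, and the same holds for the two other compounds.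

The change under review leads to compound 4 (`N#CCCN(Cc1ccco1)S(=O)(=O)c1ccc(C(F)(F)F)cc1`): furan-2-yl in place of thiophen-2-yl on a saturated chain carbon bound to a sulfonamide nitrogen with furan-2-yl in place of thiophen-2-yl on a saturated chain carbon bound to a sulfonamide nitrogen.

The measured steps bear on this only indirectly, as each alters the group on an aromatic carbon and leaves the thiophen-2-yl untouched. They are a step that the two limits leave unreadable from compound 1 to compound 2 and a step that the two limits leave unreadable from compound 1 to compound 3 and a step that the two limits leave unreadable from compound 2 to compound 3 and none has a readable size. No step beyond the scatter is therefore expected in this assay, and no direction can be assigned. The expected change is a step that the limit leaves unreadable from compound 2 to compound 4 and it stays within the scatter.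

Compound 4 is estimated at 186000 nM with an expected range from 120000 nM to 260000 nM and will probably be reported as a limit again.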

Compound 4, half-maximal cytotoxic concentration: > 186000 nM
Compound 4 gave a limit, no number; the forecaster's own chance of this, stated with the estimate: 90%; the middle value sits exactly at the limit.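

In this assay compound 2 gives > 178000 nM, a limit. Compound 4 gives > 186000 nM, again a limit, and the step between the two compounds cannot be read. The compounds shown leave open whether furan-2-yl and thiophen-2-yl differ at all in this assay.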